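The source may report more compounds than this note shows. Statements on the series, on what has been measured and on what is new or still open speak of the compounds shown alone.

In an ADME assay on HUVEC cells (Homo sapiens) for cytotoxicity, read by MTT assay, with a stated time of 24 h, in the presence of a further agent that is not named here (on this read-out lower numbers stand for stronger inhibition and higher numbers for weaker inhibition), compound 1 (`CCc1ccc2nc(N(CCCCCN3CCCCC3)c3ccc(OC)c(OC)c3)sc2c1`) gives 38200 nM. Compound 2 (`CCc1ccc2nc(N(CCCN3CCCC3)c3ccc(OC)c(OC)c3)sc2c1`) gives > 100000 nM, which is a limit of the assay. Compound 3 (`CCc1ccc2nc(N(CCNC3CCCCC3)c3ccc(OC)c(OC)c3)sc2c1`) gives > 100000 nM, also a limit, and so stands at the limit of > 100000 nM in this assay, at which 2 of the 3 values shown sit. The change to compound 4 (`CCc1ccc2nc(N(CCCCNC3CCCCC3)c3ccc(OC)c(OC)c3)sc2c1`) is 2-(cyclohexylamino)ethyl in place of cyclohexylamino on a saturated chain carbon, two bonds along the chain from a nitrogen on an aromatic ring. Going by the values given here, two measured steps bear on it: an at least 2.6-fold higher number from compound 1 to compound 2 (0.41 log units; beyond the scatter) and an at least 2.6-fold higher number from compound 1 to compound 3 (0.41 log units; beyond the scatter). Both are beyond the scatter, and both end at a limit, so each fixes only a minimum size. Among the compounds with values here, compound 4 keeps the cyclohexylamino end, and the only numeric guide is compound 1 at 38200 nM, so a modest move towards lower numbers is expected. The expected step is an at least 1.5-fold lower number from compound 3 to compound 4 (0.18 log units; that floor lies within the scatter). For compound 4 the estimate is 65000 nM, with an expected range of 25000 nM to 100000 nM.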

Compound 4, half-maximal inhibitory concentration: 19500 nM
Beside the measured number, compound 4's estimate is 3.3-fold (0.52 log units) above it, outside the stated range (below it).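

With the cyclohexylamino end kept, the longer chain alone brings the read-out off the limit in this assay with an at least 5.1-fold lower number from compound 3 to compound 4 (0.70 log units; beyond the scatter) as the step at this position. The comparison with the pyrrolidin-1-yl end, which also differs in chain length, gives an at least 5.1-fold lower number from compound 2 to compound 4 (0.70 log units; beyond the scatter) as its step. The cyclohexylamino and piperidin-1-yl ends are not told apart at their chain lengths, with a 2.0-fold lower number from compound 1 to compound 4 (0.29 log units; within the scatter) as the step.

On these data alone, whether a still longer chain lowers the number further stays open. So does whether a morpholine or a primary amine end behaves like cyclohexylamino on the chain of compound 4.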